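Thiophen swap on a shared core: what comes next

A few compounds are considered here, and "the series" means these few. Any claim that something is new, unique, unknown or untested is made for them only; others in the source may bear on it.

Within the data shown here, in a functional assay on HeLa cells (Homo sapiens) for antiproliferative activity, read by MTT assay, with a stated time of 72 h (a higher number here means a weaker inhibitor, a lower number a stronger inhibitor), compound 1 `C=C(Br)C(=O)Nc1ccc2c(c1)/C(=C/c1cccs1)C(=O)N2` gives 1700 nM and compound 2 `C=C(Br)C(=O)Nc1ccc2c(c1)/C(=C/c1ccsc1)C(=O)N2` gives 3500 nM as the higher of the two numbers so far. Among the measured compounds shown here, the one measured step is a 2.1-fold higher number from compound 1 to compound 2 (0.31 log units; beyond the scatter) and counts as modest; it swaps thiophen-2-yl for thiophen-3-yl.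

Compound 3 `C=C(Br)C(=O)Nc1ccc2c(c1)/C(=C/c1sccc1C)C(=O)N2` has not yet been measured. Its difference from compound 2 is 3-methylthiophen-2-yl in place of thiophen-3-yl on a double-bonded chain carbon bound to a double-bonded ring carbon and in words it is 3-methylthiophen-2-yl in place of thiophen-3-yl on a double-bonded chain carbon bound to a double-bonded ring carbon. The entering group returns to the thiophen-2-yl of compound 1 at 1700 nM but also carries a methyl. For the measured compounds named here, no measured step shows what that methyl does here, so the one step available is only a partial guide. In this assay, going by the values given here, a modest move toward a lower number is expected, no larger than that step, and a result within the scatter would be no surprise. The estimated step is a 1.8-fold lower number from compound 2 to compound 3 (0.24 log units; within the scatter) and remains only an expectation. Compound 3 is expected at 2000 nM with an estimated range from 800 nM to 5000 nM for now.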

Compound 3, half-maximal inhibitory concentration: 420 nM
Compound 3: the middle estimate sits 4.8-fold (0.68 log units) above what was measured, outside the stated range (below it).
By their numbers in this assay, from the lowest: compound 3; then compound 1; then compound 2.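

The clearest reading comes from the pair that differs in one place only: in this assay, methyl in place of hydrogen on an aromatic carbon gives a 4.0-fold lower number from compound 1 to compound 3 (0.61 log units; beyond the scatter). So the group on a double-bonded chain carbon bound to a double-bonded ring carbon can do more than the earlier switch between thiophen-2-yl and thiophen-3-yl showed, since a single added methyl also moves the number beyond the scatter. The step of an 8.3-fold lower number from compound 2 to compound 3 (0.92 log units; beyond the scatter) is larger still, but it changes how the thiophene ring is attached and adds the methyl at once, so it cannot assign the gain to either change alone, and nothing measured here explains why the methyl lowers the number.

Only one methylated ring is shown, so it remains open whether a methyl would also lower the number on thiophen-3-yl. It is also unknown whether a longer chain such as ethyl, or a different group such as methoxy or a chlorine atom, in place of that methyl on 3-methylthiophen-2-yl would lower the number further, leave it unchanged or raise it.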